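Flat numbers so far, and a swap at the carbonyl

The compounds below may be only part of what the source reports. "The series", "measured", "known", "first", "only" and "open" are said of these compounds alone.

In an ADME assay on HEK293 cells (Homo sapiens) for cytotoxicity, read by MTT assay, with a stated time of 72 h (a lower number here means a stronger inhibitor, a higher number a weaker inhibitor), compound 1 `Cc1ccc(C(=O)N2CCN(CC(=O)N3CCN(CCCc4c[nH]c5ccccc45)CC3)CC2)cc1` gives 159000 nM while compound 2 `Cc1ccc(C(=O)N2CCN(CC(=O)N3CCN(CCCc4c[nH]c5ccc(F)cc45)CC3)CC2)cc1` gives 141000 nM and compound 3 `COc1ccc2[nH]cc(CCCN3CCN(C(=O)CN4CCN(C(=O)c5ccc(C)cc5)CC4)CC3)c2c1` gives 147000 nM in a tight group. The data show a 1.1-fold lower number from compound 1 to compound 3 (0.03 log units; within the scatter) and a 1.0-fold higher number from compound 2 to compound 3 (0.02 log units; within the scatter) so compound 3 cannot be told apart from either of the others.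

Compound 4 `COc1ccc2[nH]cc(CCCN3CCN(C(=O)CN4CCN(C(=O)c5cccc(F)c5)CC4)CC3)c2c1` differs from compound 3 as follows: 3-fluorophenyl in place of 4-methylphenyl on a carbonyl carbon with 3-fluorophenyl in place of 4-methylphenyl on a carbonyl carbon.

Within the data shown here, no measured step touches this group. The three measured compounds differ only by fluoro, methoxy or hydrogen on an aromatic carbon of the shared core, and a 1.1-fold lower number from compound 1 to compound 2 (0.05 log units; within the scatter) adds a third small step to the two above. These steps offer only indirect guidance, since no change at the carbonyl has been measured.

The expected step is a 1.0-fold lower number from compound 3 to compound 4 (0.01 log units; within the scatter) and so none beyond the scatter is anticipated. For compound 4 an estimated 145000 nM is expected in this assay with a range from 85000 nM to 225000 nM around it.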

Compound 4, half-maximal inhibitory concentration: > 200000 nM
Compound 4 ended at the assay's limit (the forecaster's own chance of this, stated with the estimate: 10%); at least 1.3-fold (0.13 log units) between middle value and limit.
By their numbers in this assay, from the lowest: compounds 2, 3 and 1 (each within the scatter of the next). At a limit, above all of these: compound 4.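

In this assay, among these compounds, this is the first step measured at the aryl group on the carbonyl rather than on an aromatic carbon of the shared core. 3-fluorophenyl in place of 4-methylphenyl gives an at least 1.3-fold higher number from compound 3 to compound 4 (0.13 log units; that floor lies within the scatter), so the step has only a floor, and that floor cannot be told apart from the scatter. Compound 4 reads > 200000 nM, which is a limit and not a number, so the true size of the step stays unknown, and this is the only compound of the set that ends there: the limit of > 200000 nM in this assay, at which 1 of the 4 values shown sits.

As far as these compounds go, the step swaps both the substituent and its place on the ring, so the effect of each alone remains open; a plain phenyl or a 4-fluorophenyl on the carbonyl would separate them. From the compounds shown here alone, whether an amine or a carboxylic acid on that ring would bring the number down from the limit is also open.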